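The compounds below may be only part of what the source reports. "The series", "measured", "known", "first", "only" and "open" are said of these compounds alone.

Measured in a functional assay on KB cells (Homo sapiens) for cytotoxicity, read by sulforhodamine B assay; on this read-out higher numbers stand for weaker inhibition and lower numbers for stronger inhibition:
- Compound 1 `C=C1[C@@H](OC(C)=O)C[C@@H]2[C@](C)(COC=O)[C@H](OC(C)=O)CC[C@@]2(C)[C@@H]1C[C@@H](Nc1ccccc1F)C1=CCOC1=O`: 29000 nM
- Compound 2 `C=C1[C@@H](OC(C)=O)C[C@@H]2[C@](C)(CO[Si](C)(C)C(C)(C)C)[C@H](OC(C)=O)CC[C@@]2(C)[C@@H]1C[C@@H](Nc1ccccc1F)C1=CCOC1=O`: 4740 nM
- Compound 3 `C=C1[C@@H](OC(C)=O)C[C@@H]2[C@](C)(CO[Si](C)(C)C(C)(C)C)[C@H](OC(C)=O)CC[C@@]2(C)[C@@H]1C[C@@H](Nc1cccc(F)c1)C1=CCOC1=O`: 4560 nM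

Compound 1 has the highest number of the three, so it is the weakest inhibitor measured here. Compound 4 `C=C1[C@@H](OC(C)=O)C[C@@H]2[C@](C)(COC=O)[C@H](OC(C)=O)CC[C@@]2(C)[C@@H]1C[C@@H](Nc1ccc(OC)cc1)C1=CCOC1=O` has not yet been measured. It departs from compound 1 in one place, with 4-methoxyphenyl in place of 2-fluorophenyl on an amine nitrogen.

Two measured steps offer some guidance. The larger, a 6.1-fold lower number from compound 1 to compound 2 (0.79 log units; beyond the scatter), changes a group on an oxygen on a saturated carbon. Compound 4 keeps the group of compound 1 at that place, so this step does not carry over to the change at hand. For the measured compounds named here, the other, a 1.0-fold lower number from compound 2 to compound 3 (0.02 log units; within the scatter), is the only measured exchange of the aromatic group on the amine nitrogen, and it stays within the scatter. Going by the values given here, it swaps one fluorophenyl for another, however, and no measured compound carries 4-methoxyphenyl, so the support is indirect. On this basis, no change beyond the scatter is expected in this assay, and the expected step is a 1.2-fold lower number from compound 1 to compound 4 (0.08 log units; within the scatter). For compound 4 the estimated value is 24000 nM, with an expected range of 9000 nM to 60000 nM.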

Compound 4, half-maximal inhibitory concentration: 32700 nM
Beside the measured number, compound 4's estimate is 1.4-fold (0.13 log units) below it; the measured number falls inside the stated range.
By their numbers in this assay, from the lowest: compounds 3 and 2 (each within the scatter of the next); then compounds 1 and 4 (each within the scatter of the next).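

In this assay, 4-methoxyphenyl in place of 2-fluorophenyl on the amine nitrogen gives a 1.1-fold higher number from compound 1 to compound 4 (0.05 log units; within the scatter), which lies within the scatter. For the compounds shown here, the only earlier exchange at this place, a 1.0-fold lower number from compound 2 to compound 3 (0.02 log units; within the scatter), swapped one fluorophenyl for another and carried a different group on the oxygen on a saturated carbon, whereas this step replaces the fluorophenyl with a methoxy-bearing ring and keeps the group of compound 1 at that oxygen. Among these compounds, both exchanges of the aromatic group on the amine nitrogen therefore stay within the scatter, even where the entering group carries a hydrogen-bond acceptor and the leaving group carries none, and nothing available here gives a reason for this outcome.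

From the compounds shown here alone, it remains open whether the number also holds when something other than a substituted phenyl sits on the amine nitrogen, such as a pyridyl ring, a benzyl group or a short alkyl chain. Also open, going by these compounds, is whether 4-methoxyphenyl behaves the same way alongside the silicon-bearing group that compound 2 carries on the oxygen.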